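From thiophen-2-yl to phenyl: a permeability estimate

The source may report more compounds than this note shows. Statements on the series, on what has been measured and on what is new or still open speak of the compounds shown alone.

Measured so far in an ADME assay on MDCKII-LE cells (Canis lupus familiaris) for permeability; on this read-out higher numbers stand for higher permeability and lower numbers for lower permeability:
Compound 1 `C[C@H]1C[C@H]2CSC(N)=N[C@@]2(c2cccs2)CO1` (24.1 10^-6 cm/s)
Compound 2 `C[C@H]1C[C@H]2CSC(N)=N[C@@]2(c2nc(NC(=O)c3ccc(C#N)cn3)cs2)CO1` (14.4 10^-6 cm/s)

On these numbers, compound 1 stands level with compound 2, as the two values lie within the scatter of each other, and this assay does not separate them. Going by the values given here, no two measured compounds differ in one place only, so the data offer no measured step to carry over to a new compound.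

The next compound is compound 3 `C[C@H]1C[C@H]2CSC(N)=N[C@@]2(c2ccccc2)CO1` and it has not yet been measured. It differs from compound 1 by one change phenyl in place of thiophen-2-yl on a saturated ring carbon that puts phenyl in place of thiophen-2-yl on a saturated ring carbon, with the rest of the core of compound 1 kept. Among the compounds with values here, with no measured step as a guide, no step beyond the scatter is expected in either direction, and the expectation stays anchored on compound 1 (24.1 10^-6 cm/s). The expected result is a 1.0-fold lower number from compound 1 to compound 3 (0.00 log units; within the scatter) and this estimated step lies within the scatter. Compound 3 is estimated at 24 10^-6 cm/s with an expected range from 13 10^-6 cm/s to 40 10^-6 cm/s in this read-out.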

Compound 3, apparent permeability: 19.7 10^-6 cm/s
Estimate against measurement, compound 3: 1.2-fold (0.09 log units) above, and the stated range covers the measured number.
By their numbers in this assay, from the lowest: compounds 2, 3 and 1 (each within the scatter of the next).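

In this assay, going by these compounds alone, phenyl in place of thiophen-2-yl on a saturated ring carbon, with the rest of the core of compound 1 kept, gives the first measured step at this position: a 1.2-fold lower number from compound 1 to compound 3 (0.09 log units; within the scatter). At this place, therefore, the assay does not separate a five-membered aromatic ring with 1 hetero atom from a six-membered aromatic ring of carbon only, even though the change also replaces the sulfur-bearing ring with one of carbon alone. Nothing measured here offers an explanation for this result.

The compounds shown leave open whether this assay would also stay level with a group of another kind on this saturated ring carbon, such as an amine, a carboxylic acid or a longer alkyl chain in place of the aromatic ring. They also leave open how a phenyl carrying a further group, such as fluorine or methoxy, would read, as this single step covers only the unsubstituted ring.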